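A few compounds are considered here, and "the series" means these few. Any claim that something is new, unique, unknown or untested is made for them only; others in the source may bear on it.

Working notes on the series. Compound 1 `CNC(=O)/C=C1/COc2cc(OS(=O)(=O)c3cccc(Cl)c3)ccc21` and compound 2 `CNC(=O)/C=C1/COc2cc(OS(=O)(=O)c3ccc(OC)cc3)ccc21` share one core and differ only in the group on the sulfonyl sulfur. In an assay (strain Sprague-Dawley) for inhibition of Amine oxidase [flavin-containing] B (Rattus norvegicus), read by spectrophotometry, with a stated time of 5 min, tested at 10 uM (on this read-out lower numbers stand for less inhibition and higher numbers for more inhibition at the one concentration tested (going by the name of the read-out)), compound 1 gives 0%, and in this assay compound 2 gives 0%. Among the compounds with values here, the single step measured so far, no change at the digits printed from compound 1 to compound 2 (within the scatter), left the read-out where it was, so compound 2 stands level with compound 1 at the floor of the read-out.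

Compound 3 `CNC(=O)/C=C1/COc2cc(OS(=O)(=O)CCC(F)(F)F)ccc21` has not yet been measured. It differs from compound 2 as follows: 3,3,3-trifluoropropyl in place of 4-methoxyphenyl on a sulfonyl sulfur. Within the data shown here, the only step that bears on a change at the sulfonyl sulfur is no change at the digits printed from compound 1 to compound 2 (within the scatter), which stayed within the scatter; a group with no ring at this position has not been tried, so that part of the change has no precedent here. With both measured compounds at the floor, the expected step in this assay is a number 4 percentage points higher from compound 2 to compound 3 (within the scatter), none beyond the scatter. Compound 3 is therefore estimated at 4% in this assay, with a range from 0% to 22%.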

Compound 3, a percentage reported as inhibition, at one concentration (the size of the read-out at that concentration, not a potency): 17%
Compound 3: middle estimate off by 13 percentage points, on the low side, within the range that was stated.
By their numbers in this assay, from the lowest: compounds 1 and 2 (each within the scatter of the next); then compound 3.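

In this assay, within the data shown here, the sulfonyl sulfur proves able to move the read-out: the steps of a number 17 percentage points higher from compound 2 to compound 3 (beyond the scatter) and a number 17 percentage points higher from compound 1 to compound 3 (beyond the scatter) are the first at this place beyond the scatter, though both are modest. Each step replaces a six-membered aromatic ring of carbon only with the open 3,3,3-trifluoropropyl group, so within these compounds a ring on the sulfonyl sulfur is not required for measurable inhibition at the one concentration tested. Nothing given here accounts for the rise.

The compounds shown leave open whether the rise goes with the loss of the ring or with the fluorine atoms, and a plain propyl chain on the sulfonyl sulfur would separate the two. They also leave open how far the read-out climbs with a longer chain or with an amine at the chain end.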